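Working notes on compound 1 and the amino-to-hydrogen step

This account rests on a few compounds, and the source may have more. Where it says the series, first, only, none or still open, it means among the compounds named here.

Going by the values given here, compound 1 `Nc1cccc(-c2cccc(NC(=O)C(Cl)Cl)c2)c1` is the one measured member that returns a number: in a functional assay on KB 3-1 cells (Homo sapiens) for cytotoxicity, read by MTT assay, with a stated time of 68 h (on this read-out higher numbers stand for weaker inhibition and lower numbers for stronger inhibition), compound 1 gives 26100 nM. Compound 2 `O=C(Nc1cccc(-c2cccc(C(F)(F)F)c2)c1)C(Cl)Cl` reaches only a limit in this assay, > 50000 nM. Compound 3 `O=C(Nc1cccc(-c2nccs2)c1)C(Cl)Cl` likewise returns a limit, > 50000 nM. Among the compounds with values here, the one measured step that bears on the present change is an at least 1.9-fold higher number from compound 1 to compound 2 (0.28 log units; that floor lies within the scatter), and since its floor lies within the scatter it shows only that the amino group can be replaced without a gain against (the limit of > 50000 nM in this assay, at which 2 of the 3 values shown sit). Compound 4 `O=C(Nc1cccc(-c2ccccc2)c1)C(Cl)Cl` differs from compound 1 by hydrogen in place of amino on an aromatic carbon. Compound 4 is therefore expected at a 1.5-fold higher number from compound 1 to compound 4 (0.19 log units; within the scatter), an estimated 40000 nM with a range from 15000 nM to 110000 nM.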

Compound 4, half-maximal inhibitory concentration: 46800 nM
Compound 4: middle estimate off by 1.2-fold (0.07 log units), on the low side; the range from low to high includes it.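

The step to hydrogen, a 1.8-fold higher number from compound 1 to compound 4 (0.25 log units; within the scatter), is a measured step in this assay, where an at least 1.9-fold higher number from compound 1 to compound 2 (0.28 log units; that floor lies within the scatter) gave only a floor. At this position, then, the amino group is not shown to matter: hydrogen in its place gives a number that cannot be told apart from that of compound 1. The steps of an at least 1.0-fold lower number from compound 2 to compound 4 (0.02 log units; that floor lies within the scatter) and an at least 1.0-fold lower number from compound 3 to compound 4 (0.02 log units; that floor lies within the scatter) cannot be read, because the starting compound of each returns only a limit: the limit of > 50000 nM in this assay, at which 2 of the 4 values shown sit.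

Open, going by these compounds, is whether a carboxylic acid or a methoxy group on this aromatic carbon would give a number beyond the scatter from compound 1.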